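Trifluoromethyl in place of fluoro on a urea series

The compounds below may be only part of what the source reports. "The series", "measured", "known", "first", "only" and "open" are said of these compounds alone.

Three ureas sharing one core have been measured. Compound 1 `C[C@@H](NC(=O)Nc1cccc(C(F)(F)F)c1)c1ccccc1` gives 72% in an ADME assay on the whole organism with Oryza sativa as the target, tested at 1 uM; on this read-out higher numbers stand for a weaker effect at the one concentration tested and lower numbers for a stronger effect. Compound 2 `C[C@@H](NC(=O)Nc1ccccc1F)c1ccccc1` gives 95%, and compound 3 `C[C@@H](NC(=O)Nc1cc(F)ccc1F)c1ccccc1` gives 100%, the highest of the three numbers; the step here is a number 5 percentage points higher from compound 2 to compound 3 (within the scatter), while compound 1 lies beyond the scatter below it. Compound 4 `C[C@@H](NC(=O)Nc1cc(C(F)(F)F)ccc1F)c1ccccc1` differs from compound 3 by trifluoromethyl in place of fluoro on an aromatic carbon. Among the compounds with values here, the single measured step, fluoro for hydrogen, stayed within the scatter, so it says little here; the only trifluoromethyl bearer, compound 1, shows the lowest number. A downward step is therefore expected, though modest: compound 4 is estimated at 82% (range 60% to 100%), a step of a number 18 percentage points lower from compound 3 to compound 4 (beyond the scatter).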

Compound 4, a percentage reported as activity, at one concentration (the size of the read-out at that concentration, not a potency): 70%
The estimate for compound 4 lay 12 percentage points above the measured number; low and high end bracket the measured number.
By their numbers in this assay, from the lowest: compounds 4 and 1 (each within the scatter of the next); then compounds 2 and 3 (each within the scatter of the next).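

At this position, para to a fluoro group, trifluoromethyl shifts the read-out in this assay where fluoro did not: trifluoromethyl in place of fluoro gives a number 30 percentage points lower from compound 3 to compound 4 (beyond the scatter), and trifluoromethyl in place of hydrogen gives a number 25 percentage points lower from compound 2 to compound 4 (beyond the scatter). Fluoro in place of hydrogen gives a number 2 percentage points lower from compound 1 to compound 4 (within the scatter), so adding fluoro shifts little on either core: the same change on two cores in this assay, a number 5 percentage points higher (within the scatter) from compound 2 to compound 3 and a number 2 percentage points lower (within the scatter) from compound 1 to compound 4, 7 percentage points apart, within the scatter of two such steps

Still open, on these data alone, is whether a step of this size is specific to trifluoromethyl, or whether a methyl group, a nitrile or an amine at this position would give a similar one.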